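This account rests on a few compounds, and the source may have more. Where it says the series, first, only, none or still open, it means among the compounds named here.

Measured compounds:
Compound 1, `C=C1C[C@]23C[C@@]1(O)CC[C@H]2c1ccc(O)c(C)c1[C@@H]3Cn1cc(-c2ccc(C)cc2)nn1`. In a functional assay on SMMC-7721 cells (Homo sapiens) for cytotoxicity, read by MTT assay, with a stated time of 4 days (on this read-out higher numbers stand for weaker inhibition and lower numbers for stronger inhibition), compound 1 gives > 20000 nM, which is a limit of the assay rather than a number.
Compound 2, `C=C1C[C@]23C[C@@]1(O)CC[C@H]2c1cc(Br)c(O)c(C)c1[C@@H]3Cn1cc(-c2ccc(C)cc2)nn1`. In this assay compound 2 gives > 20000 nM, again a limit of the assay and not a number.
Compound 3, `C=C1C[C@]23C[C@@]1(O)CC[C@H]2c1cc(Br)c(O)c(C)c1[C@@H]3Cn1cc(-c2ccc(Cl)cc2)nn1`. In this assay, within the data shown here, compound 3 gives 19100 nM, the only number among the three.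

Compound 4, `C=C1C[C@]23C[C@@]1(O)CC[C@H]2c1ccc(O)c(C)c1[C@@H]3Cn1cc(-c2ccc(Cl)cc2)nn1`, has not yet been measured. It differs from compound 3 in one place: hydrogen in place of bromo on an aromatic carbon. The same change has been made once before among these compounds, from compound 2 to compound 1: hydrogen in place of bromo on an aromatic carbon. Both changes sit at a place described in the same words, so they count as the same change. Its measured effect, however, is a step that the two limits leave unreadable from compound 2 to compound 1, and it cannot be read because of the limit of > 20000 nM in this assay, at which 2 of the 3 values shown sit, at which both compound 2 and compound 1 sit. The two cores differ in one place as well: chloro in place of methyl on an aromatic carbon. That step is an at least 1.0-fold lower number from compound 2 to compound 3 (0.01 log units; that floor lies within the scatter), so compound 2 and compound 3 are not separated by more than the ordinary scatter.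

Among the measured compounds shown here, with the step from compound 2 to compound 1 unreadable, the expectation for compound 4 rests on compound 3 alone, whose value 19100 nM is the one number available. For the measured compounds named here, the expected step is a 1.2-fold higher number from compound 3 to compound 4 (0.06 log units; within the scatter), a small one, since the single comparison at hand gives no sign that taking away the bromo shifts the read-out. Compound 4 is therefore estimated at 22000 nM, with a likely range from 9000 nM to 50000 nM. There is a real chance that the assay returns only a limit for compound 4.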

Compound 4, half-maximal inhibitory concentration: > 20000 nM
Compound 4: only a limit was reported (the forecaster's own chance of this, stated with the estimate: 60%); the middle value is on the limit's open side.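

In this assay compound 4 gives > 20000 nM, which is a limit of the assay and not a number. Putting hydrogen in place of the bromo on the core that carries chloro gives an at least 1.0-fold higher number from compound 3 to compound 4 (0.01 log units; that floor lies within the scatter), so this change is neither shown to matter nor shown to be without effect on that core. The steps from compound 2 to compound 1 and from compound 1 to compound 4 cannot be read, so there are no two sizes to set side by side and the transfer of the change between the two cores is neither confirmed nor refuted, because most values sit at one edge of the assay: the limit of > 20000 nM in this assay, at which 3 of the 4 values shown sit.

The compounds shown leave open whether another group in place of the methyl or chloro, such as an amine or a carboxylic acid, would give values clear of that limit, where the effect of the bromo could be measured as a real step. They also leave open whether a group other than bromo at the same aromatic carbon, such as a nitrile, would separate from hydrogen there.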